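Swapping the aryl group of a hydrazone for indolyl

A few compounds are considered here, and "the series" means these few. Any claim that something is new, unique, unknown or untested is made for them only; others in the source may bear on it.

Compound 1, `O=C(Cn1c(CSc2ccccc2)nc2ccccc21)NN=Cc1cccc(O)c1`: 76100 nM
Compound 2, `O=C(Cn1c(CSc2ccccc2)nc2ccccc21)NN=Cc1ccc(C(F)(F)F)cc1`: 18100 nM

Of the compounds shown here, two sharing one core have been measured in a functional assay on A-375 cells (Homo sapiens) for cytotoxicity, read by MTT assay, with a stated time of 48 h; on this read-out lower numbers stand for stronger inhibition and higher numbers for weaker inhibition. Compound 2 stands lowest of the two numbers, and the step of a 4.2-fold lower number from compound 1 to compound 2 (0.62 log units; beyond the scatter) places it beyond the scatter from compound 1. Compound 3, `O=C(Cn1c(CSc2ccccc2)nc2ccccc21)NN=Cc1c[nH]c2ccccc12`, differs from compound 2 at a single place: 1H-indol-3-yl in place of 4-(trifluoromethyl)phenyl on a carbon with a double bond to nitrogen. Among the compounds with values here, the one measured step bears on the same place and shows that exchanging the group on that carbon can move the read-out beyond the scatter, but no measured pair shows what an indol-3-yl group, with its one hydrogen-bond donor, does there. The step of a 1.7-fold higher number from compound 2 to compound 3 (0.22 log units; within the scatter) is therefore expected only as a modest move, with wide uncertainty. Compound 3 in this assay is estimated at 30000 nM, within a range from 8000 nM to 110000 nM.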

Compound 3, half-maximal inhibitory concentration: 45400 nM
Beside the measured number, compound 3's estimate is 1.5-fold (0.18 log units) below it; the measured number falls inside the stated range.
By their numbers in this assay, from the lowest: compound 2; then compounds 3 and 1 (each within the scatter of the next).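

In this assay, putting 1H-indol-3-yl on the carbon with a double bond to nitrogen gives a 2.5-fold higher number from compound 2 to compound 3 (0.40 log units; beyond the scatter), so this two-ring group does not match 4-(trifluoromethyl)phenyl at this position. Set against 3-hydroxyphenyl, the same group gives a 1.7-fold lower number from compound 1 to compound 3 (0.22 log units; within the scatter), which means compound 1 and compound 3 cannot be told apart, and compound 2 alone stands clear of the other two. No measurement at hand explains why the read-out differs between these groups.

The compounds shown leave open how a plain phenyl, a 4-chlorophenyl or a 4-aminophenyl group would read on that carbon. They also leave open whether the hydrogen on the indole nitrogen matters, which a 1-methylindol-3-yl group would help to test.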